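The source may hold more compounds than are shown below. What is called first, only, known or untested is meant among the compounds shown, and "the series" means these compounds.

Measured so far:
compound 1 `O=C(N/N=C/c1cccc(O)c1)c1cccnc1Nc1cccc(C(F)(F)F)c1` gives 35.8% in a functional assay on the whole organism (strain Wistar) for inhibition, with Rattus norvegicus as the target, read by paw edema, with a stated time of 4 h, at a dose of 10 mg/kg by the intraperitoneal route; a higher number here means more inhibition at the dose given (going by the name of the read-out), a lower number less inhibition
compound 2 `COc1ccc(/C=N/NC(=O)c2cccnc2Nc2cccc(C(F)(F)F)c2)c(OC)c1` gives 19.8% in this assay

Compound 2 stands lowest of the two numbers in this assay; its nearest neighbour is compound 1, and the step of a number 16 percentage points lower from compound 1 to compound 2 (beyond the scatter) lies beyond the scatter.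

Compound 3 `COc1ccc(/C=N/NC(=O)c2cccnc2Nc2cccc(C(F)(F)F)c2)cc1OC` is not yet measured. Compared with compound 2 the change is 3,4-dimethoxyphenyl in place of 2,4-dimethoxyphenyl on a carbon with a double bond to nitrogen. Both compounds carry two methoxy groups on the phenyl ring at that position; only their placement on the ring differs.

Among the compounds with values here, no measured step bears directly on this change. Within the data shown here, the only step available, a number 16 percentage points lower from compound 1 to compound 2 (beyond the scatter), swaps a 3-hydroxyphenyl for a 2,4-dimethoxyphenyl and so exchanges a donor-bearing ring for a dimethoxy ring; it says nothing about moving a methoxy group from one ring position to another. Among the measured compounds shown here, with no comparable step to draw on, the expectation for this assay is a step no larger than the scatter, in either direction, and the estimate is kept close to compound 2, with a wide range because the two known values of compounds 1 and 2 set the only frame.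

Compound 3 is therefore expected to give 24% in this assay, within 8% to 40%, an estimated step of a number 4.2 percentage points higher from compound 2 to compound 3 (within the scatter).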

Compound 3, a percentage reported as inhibition, in the whole organism at one dose (the size of the read-out at that dose, not a potency): 52.9%
Compound 3: middle estimate off by 28.9 percentage points, on the low side; the measured number lies above the stated range.
By their numbers in this assay, from the lowest: compound 2; then compound 1; then compound 3.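

In this assay, moving the two methoxy groups on this ring is enough to give a number 33.1 percentage points higher from compound 2 to compound 3 (beyond the scatter), although the atoms are the same and the heavy-atom, donor and acceptor counts printed for the two groups match. The earlier step from the hydroxyphenyl to the 2,4-dimethoxyphenyl could not separate the presence of two methoxy groups from their placement, but the 3,4-dimethoxyphenyl group now gives a number 17.1 percentage points higher from compound 1 to compound 3 (beyond the scatter), so among these three compounds a dimethoxy ring does not by itself go with the lowest number, and a hydroxy group on the ring is not needed for the highest. No measurement here accounts for the effect of the placement.

Still open, from the compounds shown here alone, is how a phenyl ring with a single methoxy group, or one carrying an amine or a carboxylic acid in place of a methoxy group, would compare with the 3,4-dimethoxyphenyl group in this assay. Also open is whether the order of these three compounds would hold at other doses and times, since only one dose and one time are shown.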